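Aryl swap in the amidinoylurea series: compound 4

The source may hold more compounds than are shown below. What is called first, only, known or untested is meant among the compounds shown, and "the series" means these compounds.

Compound 3 `Cc1ccc(C(C)NC(=O)/N=C(\N)NCCCc2sc(N)nc2C)cc1` in a functional assay on Right cardiac atrium for agonist activity at histamine H2 receptor (Cavia porcellus), with a stated time of 30 min, in the presence of a further agent that is not named here (on this read-out lower numbers stand for smaller maximal responses and higher numbers for larger maximal responses), gives 0.85. Compound 1 `Cc1nc(N)sc1CCCN/C(N)=N/C(=O)NC(C)c1cccc(F)c1` gives 0.85, and the step of no change at the digits printed from compound 1 to compound 3 (within the scatter) lies within the scatter, so compounds 1 and 3 share the highest number among the three. Compound 2 `Cc1nc(N)sc1CCCN/C(N)=N/C(=O)NC(C)c1ccc(OC(F)(F)F)cc1` gives 0.61, and the step a number 0.24 higher from compound 2 to compound 3 (beyond the scatter) is the one clear difference here.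

Compound 4 `Cc1nc(N)sc1CCCN/C(N)=N/C(=O)NC(C)c1ccccc1F` has not been measured in this assay. It differs from compound 3 by 2-fluorophenyl in place of 4-methylphenyl on a saturated chain carbon bound to an amide-type nitrogen and a saturated chain carbon. For the measured compounds named here, of the two measured steps, the one from compound 1 to compound 3 is the closer analogue, since there also a fluorophenyl group stood against the 4-methylphenyl group and the read-out did not move beyond the scatter. The 2-fluorophenyl group of compound 4 is not the same group as the 3-fluorophenyl group of compound 1, so the parallel is only partial. The step from compound 2 to compound 3 concerns a different substituent and bears less directly on the change.

The expectation for compound 4 is therefore a step of a number 0.030 lower from compound 3 to compound 4 (within the scatter), inside the scatter, in this assay. The estimated value for compound 4 is 0.82, with a range from 0.65 to 0.95.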

Compound 4, intrinsic activity: the largest response reached, as a fraction of the reference agonist's: 0.93
The estimate for compound 4 lay 0.11 below the measured number; the measured number falls inside the stated range.
By their numbers in this assay, from the lowest: compound 2; then compounds 1, 3 and 4 (each within the scatter of the next).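

In this assay, the 2-fluorophenyl group on a saturated chain carbon bound to an amide-type nitrogen and a saturated chain carbon stands level with the 4-methylphenyl group (a number 0.080 higher from compound 3 to compound 4 (within the scatter)) and with the 3-fluorophenyl group (a number 0.080 higher from compound 1 to compound 4 (within the scatter)). For the compounds shown here, this read-out therefore does not separate these three aryl groups at this place, and the one clear step remains the one involving the trifluoromethoxy group of compound 2. Nothing at hand accounts for these results.

Still open, on these data alone, is whether a 4-fluorophenyl group, a 2-chlorophenyl group or a pyridine ring at this place would keep the number at this level. Also open, as far as these compounds go, is whether a cyclohexyl group, which carries no aromatic ring, would do the same.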